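Thiazolyl to Chlorophenyl in a Weakly Antiproliferative Amide Series

This account rests on a few compounds, and the source may have more. Where it says the series, first, only, none or still open, it means among the compounds named here.

Three amides on one shared core have been tested in a functional assay on HeLa cells (Homo sapiens) for antiproliferative activity, read by MTT assay, with a stated time of 72 h; on this read-out higher numbers stand for weaker inhibition and lower numbers for stronger inhibition. Compound 1 `O=C(Nc1ccc(Cl)c(-c2nnc3c(Cl)cccn23)c1)c1ccc(C(F)(F)F)cc1Cl` gives only a limit of the assay, > 100000 nM. Compound 2 `O=C(Nc1ccc(Cl)c(-c2nnc3c(Cl)cccn23)c1)c1ccc(F)cc1Cl` likewise stops at a limit, > 100000 nM. Among the compounds with values here, compound 3 `Cc1nc(C(=O)Nc2ccc(Cl)c(-c3nnc4c(Cl)cccn34)c2)cs1` is the sole compound with a number, 79800 nM. The step that the two limits leave unreadable from compound 1 to compound 2. The step of an at least 1.2-fold lower number from compound 2 to compound 3 (0.09 log units; that floor lies within the scatter). Compound 4 `O=C(Nc1ccc(Cl)c(-c2nnc3c(Cl)cccn23)c1)c1ccc(Cl)cc1` is not yet measured; from compound 3 it differs by 4-chlorophenyl in place of 2-methyl-1,3-thiazol-4-yl on a carbonyl carbon. Both carbon-only ring amides, compound 1 and compound 2, sit at the limit of > 100000 nM in this assay, at which 2 of the 3 values shown sit, so a higher number or again a limit is expected for compound 4 in this assay. Compound 4 is therefore estimated at 100000 nM, between 40000 nM and 250000 nM, an expected step of a 1.3-fold higher number from compound 3 to compound 4 (0.10 log units; within the scatter).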

Compound 4, half-maximal inhibitory concentration: > 100000 nM
Compound 4: only a limit was reported (the forecaster's own chance of this, stated with the estimate: 60%); the middle value lies on the limit itself.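

In this assay, 4-chlorophenyl in place of 2-methyl-1,3-thiazol-4-yl on this carbonyl carbon gives an at least 1.2-fold higher number from compound 3 to compound 4 (0.09 log units; that floor lies within the scatter), so this change has no size that can be told apart from the scatter. Within the data shown here, a third amide with a carbon-only ring now stops at the limit, and compound 3 remains the only amide with a number: the limit of > 100000 nM in this assay, at which 3 of the 4 values shown sit. The steps among the limit values cannot be read.

From the compounds shown here alone, it remains open whether the thiazole ring or its methyl group matters here. Going by these compounds, it is also open whether a pyridine ring or an amine on the thiazole would move the number beyond the scatter from compound 3.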